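Flipping One Stereocentre in a Weak Inhibitor

The compounds below may be only part of what the source reports. "The series", "measured", "known", "first", "only" and "open" are said of these compounds alone.

In a functional assay on HL-60 cells (Homo sapiens), with a stated time of 4 days (on this read-out higher numbers stand for weaker inhibition and lower numbers for stronger inhibition), compound 1 `C[C@@H](NC(=O)c1[nH]cnc1C(=O)Nc1ccc(Cl)c(Cl)c1)c1ccccc1` gives 5900 nM. Compound 2 `C[C@@H](c1ccccc1)N(C)C(=O)c1[nH]cnc1C(=O)Nc1ccc(Cl)c(Cl)c1` gives 56000 nM in this assay, the higher of the two numbers, beyond the scatter from compound 1, so compound 2 is the weaker inhibitor of the pair. Compound 3 `C[C@H](c1ccccc1)N(C)C(=O)c1[nH]cnc1C(=O)Nc1ccc(Cl)c(Cl)c1` differs from compound 2 in a single respect: the two compounds have the same atoms and bonds and differ only in configuration as drawn: 1 of 1 stereo elements differ; a stereocentre at a saturated chain carbon is drawn S in compound 2 and R in compound 3. Within the data shown here, no measured pair shows what this change does in this assay, so its direction is open. Compound 3 is estimated at 40000 nM in this assay, within a range of 8000 nM to 200000 nM. The expected step from compound 2 to compound 3 is a 1.4-fold lower number from compound 2 to compound 3 (0.15 log units; within the scatter), within the scatter.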

Compound 3, half-maximal inhibitory concentration: 68800 nM
Estimate against measurement, compound 3: 1.7-fold (0.24 log units) below; low and high end bracket the measured number.
By their numbers in this assay, from the lowest: compound 1; then compounds 2 and 3 (each within the scatter of the next).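

In this assay, the stereocentre at the saturated chain carbon makes no difference that can be told from scatter once the amide-type nitrogen carries methyl, with a 1.2-fold higher number from compound 2 to compound 3 (0.09 log units; within the scatter). This is a clean comparison of the stereocentre alone: the fact that compounds 2 and 3 differ only in the configuration as drawn. The change that does register is methyl in place of hydrogen on that nitrogen, with a 12-fold higher number from compound 1 to compound 3 (1.07 log units; beyond the scatter).

As far as these compounds go, whether the configuration matters when that nitrogen keeps its hydrogen remains open. So does whether an ethyl group there would give the same result as methyl.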